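Truncating the sulfonamide side chain to methyl

A few compounds are considered here, and "the series" means these few. Any claim that something is new, unique, unknown or untested is made for them only; others in the source may bear on it.

Three measured compounds share one core and differ only in the group carried by the amine nitrogen of the sulfonamide side chain. Compound 1 `CC(C)(C)NC(=O)NCCS(=O)(=O)NC(=O)c1ccc(Nc2nc(NC3(c4ccc(Cl)cc4)CC3)nc(OCC(F)(F)F)n2)cc1` gives 93% in an ADME assay on microsomes from liver (Rattus norvegicus) for metabolic stability, with a stated time of 10 min; on this read-out higher numbers stand for a more stable compound and lower numbers for a less stable compound. Compound 2 `CC(C)(C)CNCCS(=O)(=O)NC(=O)c1ccc(Nc2nc(NC3(c4ccc(Cl)cc4)CC3)nc(OCC(F)(F)F)n2)cc1` gives 90% in this assay, and compound 3 `O=C(NS(=O)(=O)CCNCc1ccccc1)c1ccc(Nc2nc(NC3(c4ccc(Cl)cc4)CC3)nc(OCC(F)(F)F)n2)cc1` gives 100%. Compound 1 stands second highest of the three numbers, with compound 2 nearest and compound 3 furthest; the steps of a number 3 percentage points lower from compound 1 to compound 2 (within the scatter) and a number 7 percentage points higher from compound 1 to compound 3 (within the scatter) both lie within the scatter, as does a number 10 percentage points higher from compound 2 to compound 3 (within the scatter).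

Compound 4 `CS(=O)(=O)NC(=O)c1ccc(Nc2nc(NC3(c4ccc(Cl)cc4)CC3)nc(OCC(F)(F)F)n2)cc1` is not yet measured. It differs from compound 1 as follows: hydrogen in place of (((tert-butyl)carbamoyl)amino)methyl on a saturated chain carbon bound to a sulfonyl sulfur. Among the measured compounds shown here, none of the measured steps removes the chain; each merely exchanges the group on the amine nitrogen, and none moves the read-out beyond the scatter. They bear on compound 4 only loosely, showing that this part of the molecule has so far left the number unchanged within the scatter for three different groups. The expectation for this assay is therefore no step beyond the scatter, in either direction, expressed as a number 1 percentage points lower from compound 1 to compound 4 (within the scatter). Compound 4 is estimated at 92%, within a range from 78% to 100%.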

Compound 4, percent of the compound remaining: 85%
The estimate for compound 4 lay 7 percentage points above the measured number; low and high end bracket the measured number.
By their numbers in this assay, from the lowest: compounds 4, 2, 1 and 3 (each within the scatter of the next, the first and the last beyond it).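

Among the compounds shown here, removing the chain is the first change at this position to give a step beyond the scatter: in this assay, hydrogen in place of (benzylamino)methyl on a saturated chain carbon bound to a sulfonyl sulfur gives a number 15 percentage points lower from compound 3 to compound 4 (beyond the scatter) and so shows that the read-out is not wholly indifferent to what this position carries. That step is modest and holds for only one of the three reference compounds, since the same truncation gives a number 8 percentage points lower from compound 1 to compound 4 (within the scatter) and a number 5 percentage points lower from compound 2 to compound 4 (within the scatter) and both of these stay within the scatter. The series therefore supports no general statement that removing the chain lowers the number, and nothing available here accounts for the difference between these steps.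

Open, going by these compounds, is what a short group in place of methyl would do in this assay, for instance ethyl, 2-aminoethyl with a free primary amine, or a chain ending in a carboxylic acid. Also open, on these data alone, is whether the benzyl group of compound 3 alone sets that compound apart from compound 4, which a phenethyl or cyclohexylmethyl group on the same amine nitrogen would help to test.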